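The source may hold more compounds than are shown below. What is called first, only, known or untested is meant among the compounds shown, and "the series" means these compounds.

Of the compounds shown here, three built on one shared core have been measured in a functional assay on BXPC-3 cells (Homo sapiens) for inhibition, read by MTT assay, with a stated time of 7 days; a lower number here means a stronger inhibitor, a higher number a weaker inhibitor. Compound 1 `CCN(CC)S(=O)(=O)c1ccc(S(=O)(=O)N2CCC[C@@H](C(=O)NC3COC3)C2)cc1` gives 13800 nM. Compound 2 `CCN(CC)S(=O)(=O)c1ccc(S(=O)(=O)N2CCC[C@@H](C(=O)NC3CN(C(=O)NC(C)(C)C)C3)C2)cc1` carries a 1-((tert-butyl)carbamoyl)azetidin-3-yl group in place of oxetan-3-yl on an amide-type nitrogen and gives 10100 nM. That single change amounts to a 1.4-fold lower number from compound 1 to compound 2 (0.14 log units; within the scatter). Compound 3 `CC(C)c1noc(N2CCN(C(=O)[C@@H]3CCCN(S(=O)(=O)c4ccc(S(=O)(=O)NC5CC5)cc4)C3)CC2)n1` gives 6700 nM, the lowest of the three numbers; its gap to compound 2 lies within the scatter, and only its gap to compound 1 lies beyond it, so compound 3 cannot be called the strongest inhibitor of the set.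

Compound 4 `CCNS(=O)(=O)c1ccc(S(=O)(=O)N2CCC[C@@H](C(=O)N3CCN(c4nc(C(C)C)no4)CC3)C2)cc1` has not yet been measured. It differs from compound 3 in one place: ethyl in place of cyclopropyl on a sulfonamide nitrogen. Among the compounds with values here, no measured pair shows this change, nor any change at the sulfonamide nitrogen; the only measured step concerns a different nitrogen and stayed within the scatter. There is therefore nothing to point to a shift in either direction in this assay beyond the usual scatter, and the expected step is no change at the digits printed from compound 3 to compound 4 (within the scatter). Compound 4 is estimated to give 6700 nM in this assay, with a likely range from 2500 nM to 18000 nM.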

Compound 4, half-maximal inhibitory concentration: 6900 nM
Beside the measured number, compound 4's estimate is 1.0-fold (0.01 log units) below it; measured number inside the range.
By their numbers in this assay, from the lowest: compounds 3, 4, 2 and 1 (each within the scatter of the next, the first and the last beyond it).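

Within the data shown here, the sulfonamide nitrogen, whose other neighbour is the sulfonyl sulfur, now has its first measured step, which none of the earlier steps could give: in this assay the swap of cyclopropyl for ethyl amounts to a 1.0-fold higher number from compound 3 to compound 4 (0.01 log units; within the scatter) and stays within the scatter. On this evidence, the three-membered carbon ring of cyclopropyl is not needed at this nitrogen for the activity seen here, since ethyl, which has no ring, gives a number that cannot be told apart from it. No measurement on hand speaks to why the two groups read alike, so this stands as an observation without an explanation.

Among these compounds, this single pair covers only two plain carbon groups, so a longer chain such as n-butyl, an amine, a carboxylic acid or a bare hydrogen on this nitrogen could behave quite differently. On these data alone, it also remains open whether ethyl and cyclopropyl would still read alike with another group at the far amide end of the molecule, or in a cell line other than the one tested here.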